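Chloro for trifluoromethyl on the urea aryl ring

The source may report more compounds than this note shows. Statements on the series, on what has been measured and on what is new or still open speak of the compounds shown alone.

Compound 3 `COc1cc(Cl)cc(-c2nn(-c3cccc(NC(=O)Nc4ccc(Cl)c(C(F)(F)F)c4)c3)cc2-c2ccncc2)c1` gives -25.9% in a functional assay on UACC-257 cells (Homo sapiens) for inhibition, read by sulforhodamine B assay, with a stated time of 48 h, tested at 10 uM (a lower number here means a stronger effect, a higher number a weaker effect of the compound at the concentration tested), the second highest of the three numbers. Compound 1 `COc1cc(Cl)cc(-c2nn(-c3cccc(NC(=O)c4ccc(Cl)c(Cl)c4)c3)cc2-c2ccncc2)c1` gives 84.2% and compound 2 `O=C(Nc1cccc(-n2cc(-c3ccncc3)c(-c3cc(O)cc(Cl)c3)n2)c1)Nc1ccc(Cl)c(Cl)c1` gives -70.7%. Among the measured compounds shown here, the only measured step, a number 110.1 percentage points lower from compound 1 to compound 3 (beyond the scatter), pairs a urea for an amide with the change of aryl substituent and so bears only loosely on the present step. Compound 4 `COc1cc(Cl)cc(-c2nn(-c3cccc(NC(=O)Nc4ccc(Cl)c(Cl)c4)c3)cc2-c2ccncc2)c1` differs from compound 3 by chloro in place of trifluoromethyl on an aromatic carbon. Compound 2, which also carries the 3,4-dichlorophenyl urea, shows a lower number than compound 3, but its hydroxy group prevents a direct reading. Compound 4 is therefore expected to show a number 14.1 percentage points lower from compound 3 to compound 4 (beyond the scatter), a modest step downward or none beyond the scatter, with an estimated value of -40% between -85% and 10%.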

Compound 4, a percentage reported as activity, at one concentration (the size of the read-out at that concentration, not a potency): -11.5%
The estimate for compound 4 lay 28.5 percentage points below the measured number, and the stated range covers the measured number.
By their numbers in this assay, from the lowest: compound 2; then compound 3; then compound 4; then compound 1.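

In this assay, chloro in place of trifluoromethyl on the urea aryl ring gives a number 14.4 percentage points higher from compound 3 to compound 4 (beyond the scatter), a modest step, so this position changes the number less than the two other single changes now readable. With the 3,4-dichlorophenyl group held fixed, these are a number 59.2 percentage points higher from compound 2 to compound 4 (beyond the scatter), with methyl in place of hydrogen on the oxygen, and a number 95.7 percentage points lower from compound 1 to compound 4 (beyond the scatter), with the urea in place of the amide. No available measurement explains these differences. The compounds shown leave open how fluoro, bromo or nitrile at this position would compare with chloro and trifluoromethyl.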